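The source may hold more compounds than are shown below. What is called first, only, known or untested is meant among the compounds shown, and "the series" means these compounds.

Measured so far in a functional assay on CWR22R cells (Homo sapiens) for inhibition, read by MTT assay; on this read-out higher numbers stand for weaker inhibition of growth and lower numbers for stronger inhibition of growth:
compound 1 `CC1=C(/C=C/C(C)=C/C=C/C(C)=C\C(=O)Nc2cccc(F)c2)C(C)(C)CCC1n1ccnc1`: 2040 nM
compound 2 `CC1=C(/C=C/C(C)=C/C=C/C(C)=C\C(=O)NCc2ccc(O)cc2)C(C)(C)CCC1n1ccnc1`: 1860 nM

Compound 2, at 1860 nM, stands level with compound 1, since the two values lie within the scatter of each other. Not yet measured is compound 3 `CC1=C(/C=C/C(C)=C/C=C/C(C)=C\C(=O)Nc2ccccc2O)C(C)(C)CCC1n1ccnc1`, which has 2-hydroxyphenyl in place of 4-hydroxybenzyl on an amide-type nitrogen. Among the compounds with values here, one measured step bears on this change, as it falls at the same place: a 1.1-fold lower number from compound 1 to compound 2 (0.04 log units; within the scatter). That step, with 4-hydroxybenzyl in place of 3-fluorophenyl, stays within the scatter. Within the data shown here, it is a single step, and no measured compound carries 2-hydroxyphenyl, so the range is kept wide. No step beyond the scatter is expected in this assay. The expected step is a 1.0-fold higher number from compound 2 to compound 3 (0.01 log units; within the scatter). Compound 3 is estimated at 1900 nM, with an expected range of 850 nM to 4200 nM.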

Compound 3, concentration for 50% growth inhibition: 2230 nM
Compound 3: the middle estimate sits 1.2-fold (0.07 log units) below what was measured; measured number inside the range.
By their numbers in this assay, from the lowest: compounds 2, 1 and 3 (each within the scatter of the next).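

In this assay the new step, a 1.2-fold higher number from compound 2 to compound 3 (0.08 log units; within the scatter), stays within the scatter, as does a 1.1-fold higher number from compound 1 to compound 3 (0.04 log units; within the scatter), so the place on the amide-type nitrogen has now taken three different groups with no step beyond the scatter. With a hydroxyl present in both groups, 2-hydroxyphenyl and 4-hydroxybenzyl are not separated by this read-out, and 2-hydroxyphenyl is likewise not separated from 3-fluorophenyl. No supporting data bear on why these groups read alike.

Still open, on these data alone, is whether any group at this place can move the number beyond the scatter, for example a longer chain ending in an amine or a carboxylic acid. Also open, as far as these compounds go, is whether the shared core would tolerate such changes equally, as all three compounds differ only on this nitrogen.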